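This account rests on a few compounds, and the source may have more. Where it says the series, first, only, none or still open, it means among the compounds named here.

In an in vitro ADME assay on microsomes from liver (Homo sapiens) for pharmacokinetics, read by LC-MS, with a stated time of 10 min, tested at 1 uM (a higher number here means faster removal of the compound, a lower number slower removal), compound 1 (`CN1C[C@H](C(=O)Nc2ccc(F)cc2)[C@@H](c2ccc(/C=C/C(=O)Nc3ccccc3N)cc2)C1`) gives 5 mL/min/kg and compound 2 (`CN1C[C@H](C(=O)Nc2ccc(C(F)(F)F)cc2)[C@@H](c2ccc(/C=C/C(=O)Nc3ccccc3N)cc2)C1`) gives 6 mL/min/kg while compound 3 (`CN1C[C@H](C(=O)Nc2cccnc2)[C@@H](c2ccc(/C=C/C(=O)Nc3ccccc3N)cc2)C1`) gives 10 mL/min/kg and thus sits within the scatter of both. Compound 4 (`Cc1ccc(NC(=O)[C@H]2CN(C)C[C@@H]2c2ccc(/C=C/C(=O)Nc3ccccc3N)cc2)cn1`) differs from compound 3 by methyl in place of hydrogen on an aromatic carbon which turns pyridin-3-yl into 6-methylpyridin-3-yl. Among the measured compounds shown here, no measured step adds a methyl, so the nearest guides are the changes to this same aromatic group. These are a 1.2-fold higher number from compound 1 to compound 2 (0.08 log units; within the scatter) and a 2.0-fold higher number from compound 1 to compound 3 (0.30 log units; within the scatter) and a 1.7-fold higher number from compound 2 to compound 3 (0.22 log units; within the scatter) and all three stay within the scatter. The estimated change is therefore no change at the digits printed from compound 3 to compound 4 (within the scatter) with no shift beyond the scatter expected in either direction. The expected clearance of compound 4 is 10 mL/min/kg (5 mL/min/kg to 20 mL/min/kg).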

Compound 4, clearance: 8 mL/min/kg
For compound 4 the middle estimate is 1.3-fold (0.10 log units) above the measured one, and the stated range covers the measured number.
By their numbers in this assay, from the lowest: compounds 1, 2, 4 and 3 (each within the scatter of the next).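

Methyl on the aromatic carbon next to the ring nitrogen, turning pyridin-3-yl into 6-methylpyridin-3-yl, gives a 1.3-fold lower number from compound 3 to compound 4 (0.10 log units; within the scatter) in this assay, so this position accepts one added carbon with no clear effect on clearance. The new group also leaves compound 4 close to both compounds carrying a substituted phenyl, with a 1.3-fold higher number from compound 2 to compound 4 (0.12 log units; within the scatter) and a 1.6-fold higher number from compound 1 to compound 4 (0.20 log units; within the scatter) on the same amide nitrogen. No evidence is available on what lies behind these small steps.

The compounds shown leave open whether an ethyl chain, a methoxy group or an amine on this same carbon would stay as close.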